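A few compounds are considered here, and "the series" means these few. Any claim that something is new, unique, unknown or untested is made for them only; others in the source may bear on it.

Working notes on the series. Of the compounds shown here, two have numbers so far in a functional assay on MCF7 cells (Homo sapiens) for antiproliferative activity, read by sulforhodamine B assay, with a stated time of 48 h, tested at 50 uM; a higher number here means more inhibition at the concentration tested (going by the name of the read-out), a lower number less inhibition. Compound 1, `COc1cccc(C(=O)Oc2cc3c(cc2C)[C@@H](C(C)C)CC=C3C)c1`, gives 11.9% in this assay, the lowest of the two values. Compound 2, `Cc1cc2c(C(C)C)ccc(C)c2cc1OC(=O)c1cccc(C(F)(F)F)c1`, gives 41.5% in this assay, a result beyond the scatter of compound 1; the two differ in more than one place, so nothing is attributed to a single change between them.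

The next compound, compound 3, `CC1=CC[C@H](C(C)C)c2cc(C)c(OC(=O)Nc3ccccc3)cc21`, has not yet been measured in this assay. It differs from compound 1 in one place: anilino in place of 3-methoxyphenyl on a carbonyl carbon. The ester linkage of compound 1 thereby becomes a carbamate in compound 3.

Among the compounds with values here, no step between measured compounds isolates this change, so the expectation rests on the low reading of compound 1 alone. Given compound 1 at 11.9%, the step of a number 8.1 percentage points higher from compound 1 to compound 3 (within the scatter) is expected to be small and upward, within or just beyond the scatter. Compound 3 is estimated at 20% in this assay, with a range from 5% to 45%.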

Compound 3, a percentage reported as inhibition, at one concentration (the size of the read-out at that concentration, not a potency): 75.1%
Compound 3: middle estimate off by 55.1 percentage points, on the low side; the whole stated range lies below it.
By their numbers in this assay, from the lowest: compound 1; then compound 2; then compound 3.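

The carbonyl carbon of compound 1 proves to be a sensitive place in this assay: anilino in place of 3-methoxyphenyl gives a number 63.2 percentage points higher from compound 1 to compound 3 (beyond the scatter), a large step that no earlier comparison could show, since compound 1 and compound 2 differ in more than one place. Within the data shown here, the single change turns the ester linkage into a carbamate and also replaces a group counted with a hydrogen-bond acceptor by one counted with a hydrogen-bond donor, so several features move together in this one step. No measurement given here explains the step.

The compounds shown leave open whether the step belongs to the linking nitrogen with its hydrogen or to the loss of the methoxy group; 3-methoxyanilino on the same carbonyl carbon would separate the two. Also open, on these data alone, is how much room this position offers beyond the plain aromatic ring, for instance for benzylamino, and whether the same change would carry over to the core of compound 2.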